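A Trifluoromethyl Group Added to the Benzyl Ring

A few compounds are considered here, and "the series" means these few. Any claim that something is new, unique, unknown or untested is made for them only; others in the source may bear on it.

Compound 1, `C=C(Br)C(=O)Nc1cccc(/C=C2\SC(=O)N(Cc3ccc(Cl)cc3)C2=O)c1`, gives 940 nM in a functional assay on L1210 cells (Mus musculus) for cytotoxicity, read by cell counting, with a stated time of 2 days; on this read-out higher numbers stand for weaker inhibition and lower numbers for stronger inhibition.
Compound 2, `Nc1ccc(/C=C2\SC(=O)N(Cc3ccccc3)C2=O)cc1`, gives 38000 nM in this assay.
Compound 3, `C=C(Br)C(=O)Nc1ccc(/C=C2\SC(=O)N(Cc3ccccc3)C2=O)cc1`, gives 1100 nM in this assay.

Among the three measured compounds, compound 3 holds the second highest number, but its gap to compound 1 lies within the scatter, while compound 2 stands well apart from it. Among the compounds with values here, the one step that can be read directly, a 35-fold lower number from compound 2 to compound 3 (1.54 log units; beyond the scatter), shows how much the (1-bromoethenyl)carbonyl group on the aromatic nitrogen matters in this assay.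

Compound 4, `C=C(Br)C(=O)Nc1ccc(/C=C2\SC(=O)N(Cc3ccc(C(F)(F)F)cc3)C2=O)cc1`, keeps that group and instead carries a change at the other end of the molecule: trifluoromethyl in place of hydrogen on an aromatic carbon. Within the data shown here, no measured step speaks to this position. Compound 1 carries a chlorine on the same ring, but it differs from compound 3 in two places, so only its value can be set beside that of compound 3, and the two lie within the scatter. With nothing in the data pointing to a shift, the step of a 1.1-fold lower number from compound 3 to compound 4 (0.04 log units; within the scatter) is expected to stay within the scatter. Compound 4 is therefore estimated at 1000 nM in this assay, with a range from 400 nM to 2500 nM.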

Compound 4, half-maximal inhibitory concentration: 12000 nM
For compound 4 the middle estimate is 12-fold (1.08 log units) below the measured one; measured number outside the range, above it.
By their numbers in this assay, from the lowest: compounds 1 and 3 (each within the scatter of the next); then compound 4; then compound 2.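

In this assay, the step of an 11-fold higher number from compound 3 to compound 4 (1.04 log units; beyond the scatter) shows that this end of the molecule does not tolerate every change, and its direction is towards weaker inhibition. The (1-bromoethenyl)carbonyl group stays in place here, and only phenyl becomes 4-(trifluoromethyl)phenyl, so the large shift belongs to this one change at the aromatic carbon para to a large group. Until now, the only step that could be read concerned the aromatic nitrogen at the other end of the molecule, whereas this one shows that the benzyl end can matter just as clearly, and no measurement shown here explains why the number rises.

Still open, going by these compounds, is whether the rise is tied to trifluoromethyl or would follow other groups on this carbon, which a fluorine, a methyl group or a methoxy group would help to separate. Compound 1 carries a chlorine on this ring but differs from compound 3 in two places, so no step can be read for chlorine at all.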